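Moving the methylsulfonyl group on the pendant phenyl ring

The source may hold more compounds than are shown below. What is called first, only, known or untested is meant among the compounds shown, and "the series" means these compounds.

Compound 3 `CC(C)S(=O)(=O)c1ccc(-c2c[nH]c3c(=O)n(Cc4cc(F)ccc4C#N)c(N4CCC[C@@H](N)C4)nc23)cc1` is one of three analogues sharing a core in which a fluorinated benzonitrile-bearing side chain and a chiral aminopiperidine are held constant while the aryl group on the five-membered ring varies. In an ADME assay on microsomes from liver (Rattus norvegicus) for metabolic stability, read by LC-MS, tested at 1 mM (on this read-out higher numbers stand for a longer-lived compound and lower numbers for a shorter-lived compound), compound 3 reaches only a limit of the assay, > 3.33 h. Compound 2 `N#Cc1ccc(F)cc1Cn1c(N2CCC[C@@H](N)C2)nc2c(-c3ccc(S(N)(=O)=O)cc3)c[nH]c2c1=O` likewise gives only a limit in this assay, > 3.33 h. Compound 1 `CS(=O)(=O)c1cccc(-c2c[nH]c3c(=O)n(Cc4cc(F)ccc4C#N)c(N4CCC[C@@H](N)C4)nc23)c1`, which carries 3-(methylsulfonyl)phenyl, gives 1.65 h in this assay, so that an at least 2.0-fold higher number from compound 1 to compound 3 (0.30 log units; that floor lies within the scatter) and an at least 2.0-fold higher number from compound 1 to compound 2 (0.30 log units; that floor lies within the scatter), while a step that the two limits leave unreadable from compound 2 to compound 3. Two of the three values sit at the same ceiling (the limit of > 3.33 h in this assay, at which 2 of the 3 values shown sit), so compound 3 stands only as a limit.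

Compound 4 `CS(=O)(=O)c1ccccc1-c1c[nH]c2c(=O)n(Cc3cc(F)ccc3C#N)c(N3CCC[C@@H](N)C3)nc12` is not yet measured. It differs from compound 3 in one place: 2-(methylsulfonyl)phenyl in place of 4-(isopropylsulfonyl)phenyl on an aromatic carbon. Among the measured compounds shown here, the nearest measured step is the one from compound 1 to compound 3, which went upward on taking the isopropylsulfonyl group in place of the methylsulfonyl group, yet its floor lies within the scatter. Returning to a methylsulfonyl group, now in the 2-position, is therefore expected to give a step downward for compound 4, an at least 1.8-fold lower number from compound 3 to compound 4 (0.26 log units; that floor lies within the scatter), toward the value of compound 1. The half-life of compound 4 in this assay is estimated at 1.8 h, within 0.8 h to 3.33 h.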

Compound 4, half-life: 3.29 h
Compound 4: the middle estimate sits 1.8-fold (0.26 log units) below what was measured; the range from low to high includes it.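

With 2-(methylsulfonyl)phenyl on the aromatic carbon two ring bonds from the ring nitrogen, compound 4 gives a number in this assay and not a limit, so a second sulfonyl-bearing phenyl group at this place now has a readable half-life alongside that of compound 1. Taking 2-(methylsulfonyl)phenyl in place of 3-(methylsulfonyl)phenyl gives a 2.0-fold higher number from compound 1 to compound 4 (0.30 log units; within the scatter), so this change of the methylsulfonyl group's place on the phenyl ring cannot be told apart from the scatter. Against the other two compounds only floors can be read, an at least 1.0-fold lower number from compound 3 to compound 4 (0.00 log units; that floor lies within the scatter) and an at least 1.0-fold lower number from compound 2 to compound 4 (0.00 log units; that floor lies within the scatter), so 2-(methylsulfonyl)phenyl cannot be ranked against 4-(isopropylsulfonyl)phenyl or 4-sulfamoylphenyl because those two compounds stand at a ceiling: the limit of > 3.33 h in this assay, at which 2 of the 4 values shown sit.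

Going by these compounds, the step from compound 2 to compound 3 cannot be read, and how far either lies from compound 4 remains open. Also open, on these data alone, is how the half-life would answer to a carboxylic acid or an amine on the pendant phenyl ring in place of the sulfonyl group.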